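Benzyl to 2-bromophenyl: working notes on compound 3

The source may hold more compounds than are shown below. What is called first, only, known or untested is meant among the compounds shown, and "the series" means these compounds.

In a functional assay on HeLa cells (Homo sapiens) for antiproliferative activity, read by sulforhodamine B assay, with a stated time of 72 h (a higher number here means a weaker inhibitor, a lower number a stronger inhibitor), compound 1 `COc1ccc(C)cc1NC(=S)N/N=C/c1ccc2ccccc2n1` gives > 100000 nM, which is a limit of the assay and not a number. Among the compounds with values here, compound 2 `S=C(NCc1ccccc1)N/N=C/c1ccc2ccccc2n1` gives 62800 nM, the only true number available so far, so it has no measured neighbour to be ranked against. Compound 3 `S=C(N/N=C/c1ccc2ccccc2n1)Nc1ccccc1Br` carries 2-bromophenyl in place of benzyl on an amide-type nitrogen. Within the data shown here, no measured step exists in this assay to size this change, and the data favour no direction. The working expectation is therefore a change a 1.0-fold lower number from compound 2 to compound 3 (0.02 log units; within the scatter) that stays within the usual scatter, with compound 2 at 62800 nM as the sole reference. For compound 3 the estimated value is 60000 nM, with an expected range of 12000 nM to 100000 nM.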

Compound 3, half-maximal inhibitory concentration: > 100000 nM
Compound 3 ended at the assay's limit; the forecaster's own chance of this, stated with the estimate: 35%; at least 1.6-fold (0.22 log units) between middle value and limit.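

In this assay compound 3 gives > 100000 nM, which is a limit of the assay and not a number. The step reads as an at least 1.5-fold higher number from compound 2 to compound 3 (0.20 log units; that floor lies within the scatter), so 2-bromophenyl in place of benzyl on this amide-type nitrogen shows no gain, and only a floor is available for the size of the change. Of the compounds shown, only compound 2, with benzyl, gives a true number at this position, and the others sit at the limit: the limit of > 100000 nM in this assay, at which 2 of the 3 values shown sit.

On these data alone, whether this change costs activity beyond the scatter remains open, since the true value of compound 3 is unknown. Also open, as far as these compounds go, is whether a longer chain ending in phenyl, or a dimethylaminoethyl group, on this nitrogen would give a lower number than compound 2.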